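Working notes on the step from compound 3 to compound 4

This account rests on a few compounds, and the source may have more. Where it says the series, first, only, none or still open, it means among the compounds named here.

Compound 1, `CN1CCN(CCNCc2cn(-c3ccc(F)cc3F)nc2-c2ccc(Cl)cc2)CC1`, gives 19000 nM in an ADME assay on Huh-7 cells (Homo sapiens) for cytotoxicity; on this read-out higher numbers stand for lower toxicity in this test and lower numbers for higher toxicity in this test.
Compound 2, `CN1CCN(CCNCc2cn(-c3ccc(F)cc3F)nc2-c2cccc(Cl)c2)CC1`, gives 15000 nM in this assay.
Compound 3, `Cc1ccccc1-c1nn(-c2ccc(OC(F)(F)F)cc2)cc1CNCCN1CCN(C)CC1`, gives 17000 nM in this assay.

Compound 3 stands second highest of the three numbers, its nearest neighbour being compound 1 and the furthest compound 2, both within the scatter of it. Compound 4, `Cc1ccccc1-c1nn(-c2ccc(F)c(F)c2)cc1CNCCN1CCN(C)CC1`, differs from compound 3 by 3,4-difluorophenyl in place of 4-(trifluoromethoxy)phenyl on an aromatic nitrogen. For the measured compounds named here, the only measured step, a 1.3-fold lower number from compound 1 to compound 2 (0.10 log units; within the scatter), concerns a different aryl group and a different position, so it bears on the change only loosely; all three values sit in one narrow band. No step beyond the scatter is therefore expected in this assay, and the estimate for compound 4 is 17000 nM, with a range from 8000 nM to 36000 nM, meaning an expected step of no change at the digits printed from compound 3 to compound 4 (within the scatter).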

Compound 4, half-maximal cytotoxic concentration: > 20000 nM
Compound 4: a limit, no number; the forecaster's own chance of this, stated with the estimate: 25%; middle value at least 1.1-fold (0.07 log units) away from the limit.
By their numbers in this assay, from the lowest: compounds 2, 3 and 1 (each within the scatter of the next). At a limit, above all of these: compound 4.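

In this assay compound 4 gives > 20000 nM, which is a limit of the assay and not a number. On the aromatic nitrogen, 3,4-difluorophenyl in place of 4-(trifluoromethoxy)phenyl, with the 2-methylphenyl group kept, gives an at least 1.1-fold higher number from compound 3 to compound 4 (0.07 log units; that floor lies within the scatter), so this swap brings no drop in the number. The true size of the step cannot be read because the value sits at a limit: the limit of > 20000 nM in this assay, at which 1 of the 4 values shown sits.

On these data alone, it remains open how far the number lies past that limit. Also open, as far as these compounds go, is how this nitrogen position would respond to an aryl group bearing a carboxylic acid or an amine.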